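The source may hold more compounds than are shown below. What is called first, only, known or untested is meant among the compounds shown, and "the series" means these compounds.

Measured so far:
Compound 1, `Nc1scc(CN2CCN(c3ccc(Cl)c(C(F)(F)F)c3)CC2)c1C(=O)c1ccc(Cl)cc1`: -2.5%
Compound 2, `Nc1scc(CN2CCN(c3cc(F)ccc3F)CC2)c1C(=O)c1ccc(Cl)cc1`: 3.1%

In a functional assay on CHO cells with adenosine receptor A1 (Homo sapiens) as the target, read by cAMP accumulation and immunoassay, with a stated time of 6 min, tested at 0.01 uM (a higher number here means a weaker effect of the compound at the concentration tested, a lower number a stronger effect), compound 1 gives -2.5%. In the same test compound 2 gives 3.1%. On the two numbers shown, compound 2 has the larger one, with compound 1 nearest, but the step of a number 5.6 percentage points higher from compound 1 to compound 2 (within the scatter) is within the scatter, so the two compounds cannot be told apart by these readings; both sit close to zero effect at the concentration tested.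

Compound 3, `Nc1scc(CN2CCN(c3ccccc3Cl)CC2)c1C(=O)c1ccc(Cl)cc1`, has not been measured yet. It differs from compound 2 in one place: 2-chlorophenyl in place of 2,5-difluorophenyl on an amine nitrogen in a ring. Within the data shown here, the only measured step bears directly on this, since it also swaps the aryl group on that same amine nitrogen in the ring: a number 5.6 percentage points higher from compound 1 to compound 2 (within the scatter), a change within the scatter. Among the measured compounds shown here, with both measured compounds giving almost no effect and the one comparable swap leaving the reading essentially unchanged, no step beyond the scatter is expected here. Compound 3 is therefore expected to give about 1% in this assay, within a range from -10% to 12%. This estimate corresponds to an expected step of a number 2.1 percentage points lower from compound 2 to compound 3 (within the scatter).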

Compound 3, a percentage reported as activity, at one concentration (the size of the read-out at that concentration, not a potency): -2.1%
Beside the measured number, compound 3's estimate is 3.1 percentage points above it, and the stated range covers the measured number.
By their numbers in this assay, from the lowest: compounds 1, 3 and 2 (each within the scatter of the next).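

In this assay, 2-chlorophenyl on the amine nitrogen in the ring gives a number 5.2 percentage points lower from compound 2 to compound 3 (within the scatter) when it replaces 2,5-difluorophenyl, and a number 0.4 percentage points higher from compound 1 to compound 3 (within the scatter) when it replaces 4-chloro-3-(trifluoromethyl)phenyl. Among these compounds, until now, this position had been probed by a single swap; there are now three different aryl groups, carrying one chlorine, two fluorines, or a chlorine with a trifluoromethyl, and no pair of them can be told apart in this test. Neither the number of halogens on the phenyl ring nor the presence of the trifluoromethyl group separates these compounds at the one concentration tested, where all three readings lie close to zero.

Going by these compounds, a reading near zero at a single concentration cannot show whether these aryl groups would differ at a higher concentration, and it remains open whether an amine or a carboxylic acid on the phenyl ring, or a longer chain in its place, would move the reading beyond the scatter. Nothing available here offers an explanation for the similar readings of the three compounds.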